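A few compounds are considered here, and "the series" means these few. Any claim that something is new, unique, unknown or untested is made for them only; others in the source may bear on it.

Measured in an ADME assay on BJ cells (Homo sapiens) for cytotoxicity, with a stated time of 72 h; on this read-out higher numbers stand for an effect only at larger amounts of compound and lower numbers for an effect already at smaller amounts:
- compound 1 `COc1ccc(/C=C/[C@@](C)(/C=C/c2ccc(O)c(/C=C/C#N)c2)CCC=C(C)C)cc1`: > 23700 nM (a limit, not a number)
- compound 2 `CCOC(=O)/C=C/c1cc(/C=C/[C@](C)(/C=C/c2ccc(OC)cc2)CCC=C(C)C)ccc1O`: > 36600 nM (a limit, not a number)
- compound 3 `COc1ccc(/C=C/[C@@](C)(/C=C/c2ccc(O)c(/C=C/C(C)=O)c2)CCC=C(C)C)cc1`: 12300 nM

Compound 3 is the only one of the three with a true number, as the other two entries are limits. Compound 4 `COc1ccc(/C=C/[C@@](C)(/C=C/c2ccc(O)c(/C=C/C(=O)c3ccccc3)c2)CCC=C(C)C)cc1` differs from it in one place: phenyl in place of methyl on a carbonyl carbon, which turns acetyl to benzoyl.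

Among the measured compounds shown here, no measured step makes this exact change. The closest is an at least 2.9-fold lower number from compound 2 to compound 3 (0.47 log units; beyond the scatter), which also alters the group on that carbonyl carbon, with methyl in place of ethoxy. Less close is an at least 1.9-fold lower number from compound 1 to compound 3 (0.28 log units; that floor lies within the scatter), where acetyl replaces cyano. The third, a step that the two limits leave unreadable from compound 1 to compound 2, cannot be read at all.

So the group on this carbonyl carbon can matter in this assay, but no measurement yet covers phenyl there. The expected change is a 1.4-fold lower number from compound 3 to compound 4 (0.14 log units; within the scatter), a small move that would stay within the scatter. For compound 4 the estimated value is 9000 nM, with an expected range from 3500 nM to 25000 nM.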

Compound 4, half-maximal effective concentration: > 36600 nM
Compound 4 gave a limit, no number (the forecaster's own chance of this, stated with the estimate: 20%); at least 4.0-fold (0.60 log units) between middle value and limit.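

In this assay, among the compounds shown here, phenyl in place of methyl on this carbonyl carbon gives the first readable step for a ring at this place: an at least 2.9-fold higher number from compound 3 to compound 4 (0.47 log units; beyond the scatter). Compound 3 thus remains the only one of these compounds with a true number, and turning its acetyl into benzoyl moves the effect to larger amounts of compound, a change that the earlier steps, which never put a ring on this carbon, could not show. The entry for compound 4 is a limit, not a number: the limit of > 36600 nM in this assay, at which 2 of the 4 values shown sit.

The steps to compound 4 from compound 1 and from compound 2 join two limits and cannot be read. From the compounds shown here alone, whether an amine or a longer chain such as propyl on this carbonyl carbon would give a true number in this assay stays open.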